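Ring methylation at the chain amine: solubility expectation

The compounds below may be only part of what the source reports. "The series", "measured", "known", "first", "only" and "open" are said of these compounds alone.

Measured values in a physicochemical assay for solubility, in the presence of a further agent that is not named here; a lower number here means a less soluble compound, a higher number a more soluble compound:
compound 1 `CC1CCCC(C)N1CCNc1n[n+]([O-])c2ccccc2[n+]1[O-]` — 48000000 nM
compound 2 `Cc1ccc2c(c1)[n+]([O-])c(NCCN(C)C)n[n+]2[O-]` — > 51000000 nM, a limit of the assay rather than a number
compound 3 `Cc1ccc2c(c1)[n+]([O-])c(NCCN1CCCCC1)n[n+]2[O-]` — 45000000 nM

Compound 3 stands lowest of the two numbers in this assay, with compound 1 nearest, and those two values lie within the scatter of each other. Compound 2 sits at the limit of > 51000000 nM in this assay, at which 1 of the 3 values shown sits. For the measured compounds named here, the one step measured at the chain amine, an at least 1.1-fold lower number from compound 2 to compound 3 (0.05 log units; that floor lies within the scatter), also lies within the scatter.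

Compound 4 `Cc1ccc2c(c1)[n+]([O-])c(NCCN1C(C)CCCC1C)n[n+]2[O-]` is not yet measured. It differs from compound 3 by 2,6-dimethylpiperidin-1-yl in place of piperidin-1-yl on a saturated chain carbon, two bonds along the chain from a nitrogen on an aromatic ring. Compound 1 carries the same 2,6-dimethylpiperidin-1-yl ring on a core lacking the methyl, and its value and that of compound 3 sit within the scatter. Going by the values given here, with the only measured step at this position staying within the scatter and compound 1 showing no large shift, no change beyond the scatter is expected in this assay for this step. Compound 4 is therefore estimated at 44000000 nM, with a range from 28000000 nM to 62000000 nM. The expected step of a 1.0-fold lower number from compound 3 to compound 4 (0.01 log units; within the scatter) stays within the scatter.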

Compound 4, solubility: 48000000 nM
Estimate against measurement, compound 4: 1.1-fold (0.04 log units) below; the range from low to high includes it.
By their numbers in this assay, from the lowest: compounds 3, 1 and 4 (each within the scatter of the next). At a limit, above all of these: compound 2.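

In this assay, for the compounds shown here, the step of a 1.1-fold higher number from compound 3 to compound 4 (0.03 log units; within the scatter) gives the first direct reading of 2,6-dimethylpiperidin-1-yl in place of piperidin-1-yl on one core, and it stays within the scatter. The methyl in place of hydrogen on an aromatic carbon, with the 2,6-dimethylpiperidin-1-yl ring held fixed, is now also read directly: the step shows no change at the digits printed from compound 1 to compound 4 (within the scatter). The step of an at least 1.0-fold lower number from compound 2 to compound 4 (0.02 log units; that floor lies within the scatter) gives only a floor, its starting value being a limit of the assay rather than a number: the limit of > 51000000 nM in this assay, at which 1 of the 4 values shown sits.

From the compounds shown here alone, whether a morpholine, a carboxylic acid or a longer chain at this position would move the number beyond the scatter stays open. Every number shown lies within the scatter of its neighbour, so the compounds shown reveal no change at this position that would move the read-out.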